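This account rests on a few compounds, and the source may have more. Where it says the series, first, only, none or still open, it means among the compounds named here.

Working notes on the series. Compound 1 `Cc1cc(Nc2cc(-c3ccccc3)[nH]n2)n2nc(SCc3ccc(F)cc3)nc2n1` gives 4020 nM in a functional assay on MCF7 cells (Homo sapiens) for inhibition, read by MTT assay, with a stated time of 72 h (on this read-out higher numbers stand for weaker inhibition and lower numbers for stronger inhibition), and is the reference for what follows. Compound 2 `Cc1cc(Nc2cc(-c3ccccc3)[nH]n2)n2nc(SCc3ccc([N+](=O)[O-])cc3)nc2n1` gives 5060 nM in this assay; the two cannot be told apart, since a 1.3-fold higher number from compound 1 to compound 2 (0.10 log units; within the scatter), and that change is nitro in place of fluoro on an aromatic carbon. Compound 3 `C=CCSc1nc2nc(C)cc(Nc3cc(-c4ccccc4)[nH]n3)n2n1` returns only a limit in this assay, > 50000 nM. The two steps onto compound 3, an at least 12-fold higher number from compound 1 to compound 3 (1.09 log units; beyond the scatter) and an at least 9.8-fold higher number from compound 2 to compound 3 (0.99 log units; beyond the scatter), are the only movements beyond the scatter seen so far, and both rest on the limit of > 50000 nM in this assay, at which 1 of the 3 values shown sits, rather than on a finished number.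

Compound 4 `Cc1ccc(CSc2nc3nc(C)cc(Nc4cc(-c5ccccc5)[nH]n4)n3n2)cc1` has not been measured. Its change from compound 1: methyl in place of fluoro on an aromatic carbon. Among the compounds with values here, the only measured step touching the same aromatic carbon is a 1.3-fold higher number from compound 1 to compound 2 (0.10 log units; within the scatter), which stayed within the scatter. The steps to compound 3 exchange the whole 4-fluorophenyl or 4-nitrophenyl for vinyl and so do not bear on a change that keeps the aryl ring. The expectation is therefore no step beyond the scatter in this assay, in either direction, which is what a 1.0-fold lower number from compound 1 to compound 4 (0.00 log units; within the scatter) is expected to mean. Compound 4 is estimated at 4000 nM, with a range of 1500 nM to 11000 nM.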

Compound 4, half-maximal inhibitory concentration: 7290 nM
Beside the measured number, compound 4's estimate is 1.8-fold (0.26 log units) below it, and the stated range covers the measured number.
By their numbers in this assay, from the lowest: compounds 1, 2 and 4 (each within the scatter of the next). At a limit, above all of these: compound 3.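

At the aromatic carbon para to a large group, methyl now stands with fluoro and nitro in this assay (first a 1.8-fold higher number from compound 1 to compound 4 (0.26 log units; within the scatter); then a 1.4-fold higher number from compound 2 to compound 4 (0.16 log units; within the scatter)), so all three groups at this place cannot be told apart. The earlier pair covered only fluoro and nitro, and the series now shows that a carbon-bound group at the same place also leaves the read-out within the scatter. Against vinyl, the 4-methylphenyl group gives a gap of the kind seen with the other two aryl groups (an at least 6.8-fold lower number from compound 3 to compound 4 (0.83 log units; beyond the scatter)), and this step too stands on the limit of compound 3 and not on a finished number: (the limit of > 50000 nM in this assay, at which 1 of the 4 values shown sits).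

Still open, going by these compounds, is whether any group on this aromatic carbon moves the number beyond the scatter, for instance an amine, a hydroxyl or a carboxylic acid. Also open, on these data alone, is what separates the aryl compounds from the vinyl compound, a question that an unsubstituted benzyl group or a longer saturated chain on the sulfur could address.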